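Swapping a propargyloxy side chain for a dimethylamino group

This account rests on a few compounds, and the source may have more. Where it says the series, first, only, none or still open, it means among the compounds named here.

Measured compounds:
compound 1 `C#CCOCC(N)C(=O)NCc1ccccc1`: 74 mg/kg
compound 2 `CCC[C@H](N)C(=O)NCc1ccccc1`: 100 mg/kg

In a functional assay on the whole organism (strain NMRI) for inhibition, with Mus musculus as the target, in the formalin test, with a stated time of 30 min (on this read-out lower numbers stand for an effect already at smaller amounts and higher numbers for an effect only at larger amounts of compound), compound 1 gives 74 mg/kg and compound 2 gives 100 mg/kg. Compound 1 stands at the lower of the two numbers, but the gap to compound 2 lies within the scatter, so the two count as alike. The unmeasured compound 3 `CN(C)CC(N)C(=O)NCc1ccccc1` keeps the core of compound 1 and changes one group: dimethylamino in place of propargyloxy on a saturated chain carbon, two bonds along the chain from an amine nitrogen and a carbonyl carbon. For the measured compounds named here, with no step between measured compounds to lean on, the expected step is a 1.2-fold higher number from compound 1 to compound 3 (0.09 log units; within the scatter), not beyond the scatter. Compound 3 is expected to give 90 mg/kg in this assay, with a range from 40 mg/kg to 200 mg/kg.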

Compound 3, dose for half-maximal effect: 83 mg/kg
Beside the measured number, compound 3's estimate is 1.1-fold (0.04 log units) above it; measured number inside the range.
By their numbers in this assay, from the lowest: compounds 1, 3 and 2 (each within the scatter of the next).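

In this assay, dimethylamino in place of propargyloxy on a saturated chain carbon, two bonds along the chain from an amine nitrogen and a carbonyl carbon, gives a 1.1-fold higher number from compound 1 to compound 3 (0.05 log units; within the scatter), a step within the scatter. At this position, then, the side chain can lose its triple bond and carry nitrogen in place of oxygen while the number stays alike. Nothing measured here explains this result. On these data alone, it remains open whether a carboxylic acid at this position would also keep the number alike. The same question stands for a longer chain ending in a primary amine.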